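Dimethylamino to diethylamino: the step to compound 3

The source may hold more compounds than are shown below. What is called first, only, known or untested is meant among the compounds shown, and "the series" means these compounds.

Compound 1 `CCN(CC)CCn1c(N)c(-c2nc3ccccc3[nH]2)c2nc(C#N)c(C#N)nc21`: 11600 nM
Compound 2 `CN(C)CCn1c(N)c(-c2nc3cc(Cl)ccc3[nH]2)c2nc(C#N)c(C#N)nc21`: > 50000 nM

In a functional assay on HeLa cells (Homo sapiens) for antiproliferative activity, read by MTT assay, with a stated time of 48 h (on this read-out higher numbers stand for weaker inhibition and lower numbers for stronger inhibition), compound 2 stands at > 50000 nM, which is a limit of the assay and not a number. Compound 3 `CCN(CC)CCn1c(N)c(-c2nc3cc(Cl)ccc3[nH]2)c2nc(C#N)c(C#N)nc21` keeps the rest of compound 2 and makes one change, diethylamino in place of dimethylamino on a saturated chain carbon, two bonds along the chain from an aromatic nitrogen. Within the data shown here, no measured step isolates this change. Among the measured compounds shown here, the only guide is compound 1, which also carries diethylamino and gives 11600 nM in this assay, though it differs from compound 3 elsewhere too. A moderate move towards stronger inhibition is therefore expected, with real doubt about its size. The estimated change is an at least 2.7-fold lower number from compound 2 to compound 3 (0.44 log units; beyond the scatter). For compound 3, the expected value is 18000 nM, with an estimated range from 6000 nM to 50000 nM.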

Compound 3, half-maximal inhibitory concentration: > 50000 nM
Compound 3 gave a limit, no number (the forecaster's own chance of this, stated with the estimate: 25%); middle value at least 2.7-fold (0.44 log units) from the limit.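

In this assay compound 3 gives > 50000 nM and this is a limit of the assay and not a number. With diethylamino held constant, chloro in place of hydrogen on an aromatic carbon gives an at least 4.3-fold higher number from compound 1 to compound 3 (0.63 log units; beyond the scatter) and so diethylamino alone does not bring the chlorinated compound to a measured number. The change from dimethylamino to diethylamino on a saturated chain carbon, two bonds along the chain from an aromatic nitrogen, cannot be read in either direction: the limit of > 50000 nM in this assay, at which 2 of the 3 values shown sit.

On these data alone, it stays open whether the two amines differ at all on the chlorinated core, since any such difference would lie beyond the reach of this read-out. Also open, as far as these compounds go, is how a pyrrolidine, a morpholine or a longer chain would behave in this place, and how fluoro or methoxy would compare with chloro.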